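Chloro to trifluoromethyl on two related isatin cores

The compounds below may be only part of what the source reports. "The series", "measured", "known", "first", "only" and "open" are said of these compounds alone.

Compound 1 `O=C1C(=O)N(CN2CCN(c3ccnc4cc(Cl)ccc34)CC2)c2cccc(Cl)c21` and compound 2 `O=C1C(=O)N(CN2CCN(c3ccnc4cc(Cl)ccc34)CC2)c2cc(Cl)ccc21` share the same atoms joined differently; the difference between their two cores is not broken down here. In a functional assay on MCF7 cells (Homo sapiens) for cytotoxicity, read by sulforhodamine B assay, with a stated time of 48 h (a lower number here means a stronger inhibitor of growth, a higher number a weaker inhibitor of growth), compound 1 gives 39100 nM and compound 2 gives 26100 nM, two values that lie within the scatter of each other. Compound 3 `O=C1C(=O)N(CN2CCN(c3ccnc4cc(C(F)(F)F)ccc34)CC2)c2cccc(Cl)c21` carries a change on the core of compound 1 (trifluoromethyl in place of chloro on an aromatic carbon), and in this assay compound 3 gives 16900 nM, a step of a 2.3-fold lower number from compound 1 to compound 3 (0.36 log units; beyond the scatter). Compound 4 `O=C1C(=O)N(CN2CCN(c3ccnc4cc(C(F)(F)F)ccc34)CC2)c2cc(Cl)ccc21` carries the same change on the core of compound 2 (trifluoromethyl in place of chloro on an aromatic carbon). For the measured compounds named here, since the single measured instance of this change gave a 2.3-fold lower number from compound 1 to compound 3 (0.36 log units; beyond the scatter), a step of similar size is expected from compound 2, giving a 2.4-fold lower number from compound 2 to compound 4 (0.38 log units; beyond the scatter). Compound 4 is therefore estimated to give about 11000 nM in this assay, most likely between 5000 nM and 25000 nM.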

Compound 4, concentration for 50% growth inhibition: 15800 nM
For compound 4 the middle estimate is 1.4-fold (0.16 log units) below the measured one, within the range that was stated.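

Carried to the second core, trifluoromethyl in place of chloro gives a 1.7-fold lower number from compound 2 to compound 4 (0.22 log units; within the scatter) in this assay and so cannot be told apart from repeat scatter on its own. Set beside the earlier step, the two do not differ in size: the same change on two cores in this assay, a 2.3-fold lower number (0.36 log units; beyond the scatter) from compound 1 to compound 3 and a 1.7-fold lower number (0.22 log units; within the scatter) from compound 2 to compound 4, 1.4-fold (0.15 log units) apart, within the scatter of two such steps. This shows that the change behaves compatibly on both cores, with the number lower in each case. For the compounds shown here, it does not show a dependable gain, since only two cores are compared and only one step lies beyond the scatter.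

The compounds shown leave open whether fluoro, methoxy or nitrile in place of chloro on that aromatic carbon would follow the same course. They also leave open what an amine or a carboxylic acid there would do.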